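4-Nitrophenyl to 3-fluorophenyl: working notes on the series

The compounds below may be only part of what the source reports. "The series", "measured", "known", "first", "only" and "open" are said of these compounds alone.

Measured in a functional assay on HepG2 cells (Homo sapiens) for cytotoxicity, read by spectrophotometry, with a stated time of 72 h; a lower number here means a stronger inhibitor, a higher number a weaker inhibitor:
- compound 1 `COc1ccc(-n2c(-c3cc(OC)c(OC)c(OC)c3)cccc2=O)cc1`: 5740 nM
- compound 2 `COc1cc(-c2cccc(=O)n2-c2ccc([N+](=O)[O-])cc2)cc(OC)c1OC`: 941 nM

Of the two measured compounds, compound 2 holds the lower number, 941 nM. The next change leads to compound 3 `COc1cc(-c2cccc(=O)n2-c2cccc(F)c2)cc(OC)c1OC`: 3-fluorophenyl in place of 4-nitrophenyl on an aromatic nitrogen. Here 3-fluorophenyl stands in place of 4-nitrophenyl on an aromatic nitrogen. Among the compounds with values here, only one measured step bears on this, a 6.1-fold lower number from compound 1 to compound 2 (0.79 log units; beyond the scatter), a modest step beyond the scatter, with nitro in place of methoxy on an aromatic carbon. Within the data shown here, no measured compound carries 3-fluorophenyl, so the transfer is loose. Like compound 1, at 5740 nM, compound 3 has no nitro group, which points to a weaker inhibitor of modest margin in this assay. The expected step is a 3.2-fold higher number from compound 2 to compound 3 (0.50 log units; beyond the scatter). For compound 3 the estimated value is 3000 nM, with an expected range of 900 nM to 10000 nM.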

Compound 3, half-maximal inhibitory concentration: 73 nM
For compound 3 the middle estimate is 41-fold (1.61 log units) above the measured one; measured number outside the range, below it.
By their numbers in this assay, from the lowest: compound 3; then compound 2; then compound 1.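

In this assay, the group on the aromatic nitrogen has a larger effect than the nitro for methoxy change alone indicated: 3-fluorophenyl in place of 4-nitrophenyl gives a large step (a 13-fold lower number from compound 2 to compound 3 (1.11 log units; beyond the scatter)), and 3-fluorophenyl in place of 4-methoxyphenyl gives a larger one (a 79-fold lower number from compound 1 to compound 3 (1.90 log units; beyond the scatter)). A nitro group is therefore not required for a low number in this series, as compound 3 has none and holds the lowest number of the three. No measurement shown here accounts for the size of these steps.

The compounds shown do not separate the contribution of the fluorine from that of its place on the phenyl ring, and an unsubstituted phenyl on the same nitrogen would bear directly on this. Also open, from the compounds shown here alone, is how an amine or a carboxylic acid on that phenyl ring would read.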